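Swapping Hydroxy for Phenyl on Compound 3

This account rests on a few compounds, and the source may have more. Where it says the series, first, only, none or still open, it means among the compounds named here.

- compound 1 `C=CCc1cc(O)c(O)c(CN2CCC(C)CC2)c1` gives 91.1%
- compound 2 `C=CCc1cc(O)c(O)c(CN2CCC(CCO)CC2)c1` gives 39.4%
- compound 3 `C=CCc1cc(O)c(O)c(CN2CCC(CO)CC2)c1` gives 37.7%

In a functional assay on HL-60 cells (Homo sapiens) for inhibition, read by MTT assay, with a stated time of 72 h, tested at 30 uM (a lower number here means less inhibition of growth, a higher number more inhibition of growth at the concentration tested), compound 3 reads 37.7% and cannot be told apart from its nearest neighbour (a number 1.7 percentage points lower from compound 2 to compound 3 (within the scatter)). Two large steps separate the hydroxy-bearing pair from the remaining compound (a number 53.4 percentage points lower from compound 1 to compound 3 (beyond the scatter) and a number 51.7 percentage points lower from compound 1 to compound 2 (beyond the scatter)).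

The next structure is compound 4 `C=CCc1cc(O)c(O)c(CN2CCC(Cc3ccccc3)CC2)c1`, in which phenyl takes the place of hydroxy on a saturated chain carbon bound to a saturated ring carbon (phenyl in place of hydroxy on a saturated chain carbon bound to a saturated ring carbon). Among the compounds with values here, no measured step makes this exact swap, and no measured compound carries phenyl, so the evidence is indirect. Like compound 1 at 91.1% and unlike compound 2 at 39.4%, compound 4 has no hydroxy. Three compounds make a thin pattern, but it points to a large rise, close in size to those two large steps and reversed in direction. The estimated step is large and upward (a number 44.3 percentage points higher from compound 3 to compound 4 (beyond the scatter)). For compound 4 the estimated value is 82% (expected range 55% to 98%).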

Compound 4, percent growth inhibition at one concentration: 90.6%
Compound 4: the middle estimate sits 8.6 percentage points below what was measured; the range from low to high includes it.
By their numbers in this assay, from the lowest: compounds 3 and 2 (each within the scatter of the next); then compounds 4 and 1 (each within the scatter of the next).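

In this assay, swapping hydrogen for phenyl on the chain carbon leaves the reading within the scatter (a number 0.5 percentage points lower from compound 1 to compound 4 (within the scatter)), so this position accepts a much larger carbon-only group with no visible loss of growth inhibition. Phenyl in place of hydroxy (a number 52.9 percentage points higher from compound 3 to compound 4 (beyond the scatter)) and in place of hydroxymethyl (a number 51.2 percentage points higher from compound 2 to compound 4 (beyond the scatter)) both give large steps, so among these four compounds the two low readings belong to the two with a hydroxy group, and group size alone does not sort them. Nothing measured here explains this pattern.

As far as these compounds go, it remains open whether an amine or a carboxylic acid at this place would read as low as the hydroxy compounds. A methyl ether or a plain longer carbon chain would show whether the free hydroxy group itself goes with the low readings.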